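This account rests on a few compounds, and the source may have more. Where it says the series, first, only, none or still open, it means among the compounds named here.

Measured so far in an ADME assay on THP-1 cells (Homo sapiens) for cytotoxicity; on this read-out lower numbers stand for stronger inhibition and higher numbers for weaker inhibition:
compound 1 `COc1ccccc1-c1nnc(-c2ccc(C(=O)N/N=C/c3ccncc3)cc2)o1` gives 173000 nM
compound 2 `COc1ccccc1-c1nnc(-c2ccc(C(=O)N/N=C/c3ccc(F)cc3)cc2)o1` gives 427000 nM
compound 3 `COc1ccccc1-c1nnc(-c2ccc(C(=O)N/N=C/c3ccc(Cl)cc3Cl)cc2)o1` gives 78800 nM

On these numbers compound 1 stands second highest of the three: the nearest neighbour is compound 3, reached by a 2.2-fold lower number from compound 1 to compound 3 (0.34 log units; beyond the scatter), the furthest is compound 2, reached by a 2.5-fold higher number from compound 1 to compound 2 (0.39 log units; beyond the scatter). Between those two the step of a 5.4-fold lower number from compound 2 to compound 3 (0.73 log units; beyond the scatter) is the largest seen in the set.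

Compound 4 `COc1ccccc1-c1nnc(-c2ccc(C(=O)N/N=C/c3cccc([N+](=O)[O-])c3)cc2)o1` differs from compound 1 in one place: 3-nitrophenyl in place of pyridin-4-yl on a carbon with a double bond to nitrogen. Among the measured compounds shown here, no measured step brings in a 3-nitrophenyl, so the expectation rests on the two steps that also replace pyridin-4-yl at this place, a 2.5-fold higher number from compound 1 to compound 2 (0.39 log units; beyond the scatter) and a 2.2-fold lower number from compound 1 to compound 3 (0.34 log units; beyond the scatter); both are modest and run in opposite directions. The step into compound 4 is therefore expected to be modest too, without a clear direction, and may well stay within the scatter. From compound 1 the expected step is a 1.2-fold lower number from compound 1 to compound 4 (0.06 log units; within the scatter). Compound 4 is expected at 150000 nM, with a range from 60000 nM to 400000 nM.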

Compound 4, half-maximal inhibitory concentration: 119000 nM
Beside the measured number, compound 4's estimate is 1.3-fold (0.10 log units) above it; the measured number falls inside the stated range.
By their numbers in this assay, from the lowest: compounds 3, 4 and 1 (each within the scatter of the next, the first and the last beyond it); then compound 2.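

In this assay, 3-nitrophenyl on a carbon with a double bond to nitrogen cannot be told apart from pyridin-4-yl (a 1.5-fold lower number from compound 1 to compound 4 (0.16 log units; within the scatter)) or from 2,4-dichlorophenyl (a 1.5-fold higher number from compound 3 to compound 4 (0.18 log units; within the scatter)), so compound 4 lies within the scatter of both compound 1 and compound 3, although those two lie beyond it from each other. Among the compounds shown here, only compound 2 stands clearly apart from compound 4 (a 3.6-fold lower number from compound 2 to compound 4 (0.55 log units; beyond the scatter)), and with its steps to compound 1 and compound 3 also beyond the scatter, 4-fluorophenyl is the one group here that separates from all the others. No measurement at hand accounts for these differences.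

As far as these compounds go, all four groups at this place are six-membered aromatic rings, so the response to a non-aromatic group such as a piperidine or a longer alkyl chain remains open. A plain phenyl or a 3-aminophenyl would show whether the nitro group itself matters to the number seen with compound 4.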